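The source may hold more compounds than are shown below. What is called first, only, known or untested is meant among the compounds shown, and "the series" means these compounds.

Compound 1 `O=C(O)/C=C/C(=O)Nc1cccc(-c2nc3ccccc3s2)c1`: in an ADME assay on HepG2 cells (Homo sapiens) for inhibition, with a stated time of 72 h (on this read-out lower numbers stand for an effect already at smaller amounts and higher numbers for an effect only at larger amounts of compound), compound 1 gives > 25000 nM, which is a limit of the assay and not a number.
Compound 2 `O=C(Nc1cccc(-c2nc3ccccc3s2)c1)c1ccncc1Cl`: in this assay compound 2 gives > 25000 nM, again a limit rather than a number.

For the measured compounds named here, compound 2 therefore stands at the limit, as does the only other compound measured; the limit of > 25000 nM in this assay, at which 2 of the 2 values shown sit, holds both values shown. Going by the values given here, the one step between measured compounds, a step that the two limits leave unreadable from compound 1 to compound 2, cannot be read, because both ends are limits. Compound 3 `O=C(Nc1cccc(-c2nc3ccccc3s2)c1)c1cnc(Cl)s1` differs from compound 2 by 2-chloro-1,3-thiazol-5-yl in place of 3-chloropyridin-4-yl on a carbonyl carbon. Among the compounds with values here, no measured step bears on this change in a readable way, so the evidence gives no direction and no size, only that every value so far sits at the limit. Compound 3 is expected to give 30000 nM in this assay, with a range of 10000 nM to 100000 nM, most likely reported again as a limit. The expected step from compound 2 to compound 3 is a step that the limit leaves unreadable from compound 2 to compound 3.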

Compound 3, half-maximal effective concentration: > 25000 nM
Compound 3: a limit, no number; the forecaster's own chance of this, stated with the estimate: 80%; the middle value lies beyond the limit too.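

In this assay compound 3 gives > 25000 nM and this is a limit, not a number. With compound 1 and compound 2 also at a limit, no step among these three compounds can be read. The compounds shown leave open whether any group on this carbonyl carbon gives a measurable value.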